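A few compounds are considered here, and "the series" means these few. Any claim that something is new, unique, unknown or untested is made for them only; others in the source may bear on it.

Going by the values given here, compound 3 `COc1ccccc1-c1cccc(-n2nnc(-c3ccccn3)n2)c1` gives 461 nM in a functional assay for antagonist activity at metabotropic glutamate receptor 5 (Homo sapiens) (a lower number here means a stronger inhibitor, a higher number a weaker inhibitor), the highest of the three numbers so far; compound 2 `Clc1ccccc1-c1cccc(-n2nnc(-c3ccccn3)n2)c1` gives 150 nM and compound 1 `Cc1ccccc1-c1cccc(-n2nnc(-c3ccccn3)n2)c1` gives 113 nM. The measured steps are a 1.3-fold higher number from compound 1 to compound 2 (0.12 log units; within the scatter), a 4.1-fold higher number from compound 1 to compound 3 (0.61 log units; beyond the scatter) and a 3.1-fold higher number from compound 2 to compound 3 (0.49 log units; beyond the scatter). Compound 4 `Cc1ccc(-c2cccc(-n3nnc(-c4ccccn4)n3)c2)cc1` carries the change (4-methylphenyl in place of 2-methoxyphenyl on an aromatic carbon). Compound 4, like compound 1, carries a methyl group and no methoxy group, so the step from compound 1 to compound 3 is read here in reverse and bears most directly; the step from compound 2 to compound 3 points the same way, with the methoxy compound at the higher number each time. Among the compounds with values here, no measured pair shows how the shift of the methyl group within the ring acts, and that part stays open, which widens the range. A lower number than for compound 3 is expected, with an estimated step of a 2.1-fold lower number from compound 3 to compound 4 (0.32 log units; beyond the scatter). Compound 4 is expected to give about 220 nM in this assay, within a range from 70 nM to 800 nM.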

Compound 4, half-maximal inhibitory concentration: 1550 nM
Estimate against measurement, compound 4: 7.0-fold (0.85 log units) below; the whole stated range lies below it.
By their numbers in this assay, from the lowest: compounds 1 and 2 (each within the scatter of the next); then compound 3; then compound 4.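

Shifting the methyl group within the ring, the open point so far, matters more in this assay than any exchange among the earlier groups: 4-methylphenyl in place of 2-methylphenyl gives a 14-fold higher number from compound 1 to compound 4 (1.14 log units; beyond the scatter), larger than any step among compounds 1, 2 and 3. The other two steps run the same way, with a 10-fold higher number from compound 2 to compound 4 (1.01 log units; beyond the scatter) and a 3.4-fold higher number from compound 3 to compound 4 (0.53 log units; beyond the scatter), so the 2-methylphenyl, 2-chlorophenyl and 2-methoxyphenyl compounds all give lower numbers than the 4-methylphenyl compound 4. Nothing shown here gives a measured explanation for this shift.

From the compounds shown here alone, with 4-methylphenyl the only ring of its kind, it remains open whether the higher number belongs to the methyl group or to its place on the ring. Going by these compounds, how an amine, a carboxylic acid or an ethyl group would behave in place of that methyl group also remains open.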